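Removing one methoxy from the trimethoxy hydroxamate

A few compounds are considered here, and "the series" means these few. Any claim that something is new, unique, unknown or untested is made for them only; others in the source may bear on it.

Measured so far in a functional assay on CAL-27 cells (Homo sapiens) for cytotoxicity, read by MTT assay (on this read-out higher numbers stand for weaker inhibition and lower numbers for stronger inhibition), are these compounds:
- compound 1 `COc1cc(C(=O)NOCCCCCC(=O)NO)cc(OC)c1OC` gives 3070 nM in this read-out
- compound 2 `CC(C)(C)c1cc(C(=O)NOCCCCCC(=O)NO)cc(C(C)(C)C)c1` gives 1000 nM in this read-out

Compound 1 holds the higher of the two numbers, and the gap down to compound 2 lies beyond the usual scatter. Compound 3 `COc1cc(OC)cc(C(=O)NOCCCCCC(=O)NO)c1` is not yet measured. It arises from compound 1 through a single change, hydrogen in place of methoxy on an aromatic carbon, ortho to two methoxy groups and para to a large group (hydrogen in place of methoxy on an aromatic carbon).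

Within the data shown here, no measured pair isolates this change, so the expectation rests on little. Among the measured compounds shown here, the only comparison is compound 2 at 1000 nM in this series, which carries no methoxy group at all but differs from compound 1 in more than that. A small move toward a lower number is therefore expected, without confidence in its direction. The estimate is a 1.4-fold lower number from compound 1 to compound 3 (0.14 log units; within the scatter) and this expected move stays within the scatter. For compound 3 the estimated value is 2200 nM in this assay with an expected range from 900 nM to 5500 nM around it.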

Compound 3, half-maximal inhibitory concentration: 720 nM
The estimate for compound 3 lay 3.1-fold (0.49 log units) above the measured number, and the stated range ends above it.
By their numbers in this assay, from the lowest: compounds 3 and 2 (each within the scatter of the next); then compound 1.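

In this assay, among these compounds, replacing the methoxy that sits para to a large group with hydrogen gives a 4.3-fold lower number from compound 1 to compound 3 (0.63 log units; beyond the scatter), and this is the first step that isolates one place on the ring. The methoxy at this position is therefore not required for cytotoxic activity on these cells, and of the two groups compared here, hydrogen gives the lower number while the two remaining methoxy groups stay unchanged. Nothing at hand gives a measured basis for explaining the size of this step.

Still open, from the compounds shown here alone, is how other groups at this same position would read out, for example a hydroxyl, a fluorine or an amine, and whether the lower number depends on the two remaining methoxy groups, which would need a compound with one or both of them replaced by hydrogen. Also open is whether this step carries over to a shorter or longer chain linking the core to the hydroxamic acid, since all the compounds shown share one chain.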